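A few compounds are considered here, and "the series" means these few. Any claim that something is new, unique, unknown or untested is made for them only; others in the source may bear on it.

Measured compounds:
- Compound 1 `COc1ccc(-c2cc(C(=O)Nc3ccc(Oc4ccnc5cc(OCCCN6CCCCC6)c(OC)cc45)c(F)c3)c3ccccc3n2)cc1`: 290 nM
- Compound 2 `COc1ccc(-c2cc(C(=O)Nc3ccc(Oc4ccnc5cc(OCCCN6CCC(C)CC6)c(OC)cc45)c(F)c3)c3ccccc3n2)cc1`: 110 nM

Both numbers come from a functional assay on NCI-H460 cells (Homo sapiens) for cytotoxicity, read by MTT assay, with a stated time of 72 h; on this read-out lower numbers stand for stronger inhibition and higher numbers for weaker inhibition. Compound 1 stands at the highest of the two numbers; its nearest neighbour is compound 2, and the step of a 2.6-fold lower number from compound 1 to compound 2 (0.42 log units; beyond the scatter) is a modest one, brought about by a methyl in place of hydrogen on a saturated ring carbon.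

Compound 3 `COc1ccc(-c2cc(C(=O)Nc3ccc(Oc4ccnc5cc(OCCCN6CCCCC6)c(OC)cc45)c(F)c3)c3cc(F)ccc3n2)cc1` has not yet been measured in this assay. Its difference from compound 1 is fluoro in place of hydrogen on an aromatic carbon, on a six-membered aromatic ring of carbon only that is part of a fused system of two rings.

For the measured compounds named here, the one measured step, from compound 1 to compound 2, concerns a saturated ring far from the place changed here and gives no guide to a fluoro on an aromatic ring. Going by the values given here, nothing among the measured compounds speaks for or against this change, so the expected step of a 1.1-fold lower number from compound 1 to compound 3 (0.05 log units; within the scatter) is none beyond the scatter. Compound 3 is therefore estimated at 260 nM, with a range from 90 nM to 750 nM.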

Compound 3, half-maximal inhibitory concentration: 240 nM
For compound 3 the middle estimate is 1.1-fold (0.03 log units) above the measured one, within the range that was stated.
By their numbers in this assay, from the lowest: compound 2; then compounds 3 and 1 (each within the scatter of the next).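

In this assay, fluoro in place of hydrogen on an aromatic carbon, on the six-membered aromatic ring of carbon only that is part of a fused system of two rings, gives a 1.2-fold lower number from compound 1 to compound 3 (0.08 log units; within the scatter), so this assay does not tell compound 3 apart from compound 1. For the compounds shown here, the earlier compounds showed only a change on a saturated ring, whereas this result is the first reading from the fused system: at this carbon, swapping hydrogen for this one heavy atom leaves the cytotoxicity read-out within ordinary repeat-to-repeat variation. No measurement shown here offers an explanation for why the fluoro makes no clear difference at this position.

Going by these compounds, it remains open whether a larger group on the same carbon, such as a chloro, a methoxy, a trifluoromethyl or an amine, would also leave the number unchanged, and whether a fluoro on the other carbons of this ring would behave in the same way. Also open, on these data alone, is what a single molecule carrying both this fluoro and the methyl found on the saturated ring of compound 2 would give.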